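This account rests on a few compounds, and the source may have more. Where it says the series, first, only, none or still open, it means among the compounds named here.

Measured so far:
- compound 1, `COc1cc(-c2nc(-c3ccccc3)[nH]c2-c2ccnc(NCCCNS(=O)(=O)c3ccc(Br)cc3)n2)ccc1F`, 33900 nM
- compound 2, `O=S(=O)(NCCCNc1nccc(-c2[nH]c(-c3ccccc3)nc2-c2ccc(F)c(O)c2)n1)c1ccc(Br)cc1`, 5660 nM

These two compounds were tested in a functional assay on LOX IMVI cells (Homo sapiens) for cytotoxicity, read by MTT assay, with a stated time of 24 h; a lower number here means a stronger inhibitor, a higher number a weaker inhibitor. Going by the values given here, compound 2 has the lowest of the two numbers, and the only step between them, a 6.0-fold lower number from compound 1 to compound 2 (0.78 log units; beyond the scatter), came from a change at a different place in the molecule than the one considered now.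

Compound 3, `COc1ccc(S(=O)(=O)NCCCNc2nccc(-c3[nH]c(-c4ccccc4)nc3-c3ccc(F)c(O)c3)n2)cc1`, is not yet measured. It differs from compound 2 by methoxy in place of bromo on an aromatic carbon. Among the compounds with values here, no measured step involves this part of the molecule, so there is nothing in the data that shows how this kind of change moves the number in this assay; the change sits far from the oxygen that carried the one known step. For that reason no shift beyond the scatter is expected, and the estimate for compound 3 is simply anchored on compound 2, with a wide range.

Compound 3 is expected to give 7000 nM, within 2500 nM to 20000 nM, which means an estimated step of a 1.2-fold higher number from compound 2 to compound 3 (0.09 log units; within the scatter).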

Compound 3, half-maximal inhibitory concentration: 13900 nM
The estimate for compound 3 lay 2.0-fold (0.30 log units) below the measured number, within the range that was stated.
By their numbers in this assay, from the lowest: compound 2; then compound 3; then compound 1.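

In this assay, the aromatic carbon para to a large group proves able to move the number: replacing bromo with methoxy there gives a modest step (a 2.5-fold higher number from compound 2 to compound 3 (0.39 log units; beyond the scatter)). Going by these compounds alone, until now, the only measured change was at the oxygen on the other aromatic ring, so this shows that the 4-bromophenyl end of the molecule also affects the result. Nothing measured here explains why the number rises with methoxy.

Going by these compounds, with only bromo and methoxy compared, it remains open how an amine, a carboxylic acid or a plain hydrogen at this carbon would read. It is also unknown whether the same swap would give a similar step when the methoxy group of compound 1 replaces the hydroxyl group on the other ring.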